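Swapping Allyl for Butylcarbonyl at the Aromatic Oxygen

The compounds below may be only part of what the source reports. "The series", "measured", "known", "first", "only" and "open" are said of these compounds alone.

Compound 2 `C=CCOc1cc(/C=C/C(=O)c2ccc(OC)c3c2OC(C)(C)C=C3)ccc1OC` and compound 1 `C#CCOc1cc(/C=C/C(=O)c2ccc(OC)c3c2OC(C)(C)C=C3)ccc1OC` share one core and differ only in the group on an oxygen on an aromatic ring. In a functional assay on HepG2 cells (Homo sapiens) for cytotoxicity, read by MTT assay (a lower number here means a stronger inhibitor, a higher number a weaker inhibitor), compound 1 gives > 10000 nM, which is a limit of the assay and not a number. In this assay compound 2 gives > 10000 nM, likewise only a limit. Both values sit at the limit of > 10000 nM in this assay, at which 2 of the 2 values shown sit, so the step that the two limits leave unreadable from compound 1 to compound 2 cannot be read. Compound 3 `CCCCC(=O)Oc1cc(/C=C/C(=O)c2ccc(OC)c3c2OC(C)(C)C=C3)ccc1OC` arises from compound 2 by butylcarbonyl in place of allyl on an oxygen on an aromatic ring. Within the data shown here, no measured step bears on this change, and compound 2 stands only at a limit. Compound 3 is expected to give about 15000 nM, between 4000 nM and 60000 nM, a step that the limit leaves unreadable from compound 2 to compound 3 that most likely stays unreadable.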

Compound 3, half-maximal inhibitory concentration: 100 nM
Beside the measured number, compound 3's estimate is 150-fold (2.18 log units) above it; measured number below the stated range.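

At the oxygen on the aromatic ring, butylcarbonyl gives what allyl and propargyl did not, a readable value in this assay, with an at least 100-fold lower number from compound 2 to compound 3 (2.00 log units; beyond the scatter) and an at least 100-fold lower number from compound 1 to compound 3 (2.00 log units; beyond the scatter). Among these three compounds, then, the group on this oxygen alone can move the number strongly. Each of these steps starts from a limit of the assay, so its true size may be larger: the limit of > 10000 nM in this assay, at which 2 of the 3 values shown sit.

On these data alone, it remains open whether the carbonyl or the chain carries the step, and whether an acetyl group, a longer chain or an amide at this oxygen would do the same.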